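Removing One Chloro from a Dichlorinated Ketoamide

This account rests on a few compounds, and the source may have more. Where it says the series, first, only, none or still open, it means among the compounds named here.

Compound 1, `O=C(CCC(=O)c1ccc(F)cc1)NCCCO`: > 400 mg/kg
Compound 2, `O=C(CCC(=O)c1ccc(Cl)c(Cl)c1)NCCCO`: 450 mg/kg

Among the compounds with values here, in a functional assay on the whole organism with Mus musculus as the target, in the maximal electroshock model (on this read-out higher numbers stand for an effect only at larger amounts of compound and lower numbers for an effect already at smaller amounts), compound 2 gives 450 mg/kg, the only actual number among the values shown. Compound 1 gives > 400 mg/kg in this assay, which is a limit of the measurement and not a number. Compound 1 thus sits at the limit of > 400 mg/kg in this assay, at which 1 of the 2 values shown sits. Compound 3, `O=C(CCC(=O)c1ccc(Cl)cc1)NCCCO`, differs from compound 2 by hydrogen in place of chloro on an aromatic carbon. Within the data shown here, no measured pair of this kind exists, so nothing fixes the size of the step; compound 3 is expected to shift by about a 1.2-fold higher number from compound 2 to compound 3 (0.09 log units; within the scatter), toward an effect at larger amounts or none beyond the scatter. Compound 3 is therefore estimated at 550 mg/kg, between 250 mg/kg and 1200 mg/kg.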

Compound 3, dose for half-maximal effect: > 300 mg/kg
Compound 3: no number, only a limit; the forecaster's own chance of this, stated with the estimate: 50%; the middle value is on the limit's open side.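

Compound 3 and compound 1 give only limits, so no step can be read from compound 2 to compound 3 or from compound 1 to compound 3. From the compounds shown here alone, whether hydrogen in place of chloro, or chloro in place of fluoro, on an aromatic carbon changes the dose needed in this assay stays open.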